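The compounds below may be only part of what the source reports. "The series", "measured", "known", "first", "only" and "open" are said of these compounds alone.

Measured compounds, inhibition in a functional assay on SR cells (Homo sapiens) for inhibition, read by sulforhodamine B assay, with a stated time of 48 h, tested at 10 uM; on this read-out higher numbers stand for more inhibition at the one concentration tested (going by the name of the read-out) and lower numbers for less inhibition:

Compound 1 `c1ccc(-c2cn3ccnc3c(-c3ccc4ncn(C5CCCCC5)c4c3)n2)cc1` gives 59.8%.
Compound 2 `Clc1ccc(-c2cn3ccnc3c(-c3ccc4ncn(C5CCCCC5)c4c3)n2)cc1` gives 18.5%.
Compound 3 `Brc1ccc(-c2cn3ccnc3c(-c3ccc4ncn(C5CCCCC5)c4c3)n2)cc1` gives 60.7%.

Compound 3 stands highest of the three numbers. Its nearest neighbour is compound 1, with the step of a number 0.9 percentage points higher from compound 1 to compound 3 (within the scatter) lying within the scatter, so the two cannot be ordered. Its furthest neighbour is compound 2, with a number 42.2 percentage points higher from compound 2 to compound 3 (beyond the scatter) well beyond the scatter. The same ring also carries a number 41.3 percentage points lower from compound 1 to compound 2 (beyond the scatter), a large fall, so within these three compounds the identity of the halogen on this phenyl matters a great deal in this assay while the bromo compound and the unsubstituted compound sit together.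

Compound 4 `Fc1ccccc1-c1cn2ccnc2c(-c2ccc3ncn(C4CCCCC4)c3c2)n1` has not yet been measured. The change from compound 3 is 2-fluorophenyl in place of 4-bromophenyl on an aromatic carbon. For the measured compounds named here, none of the measured steps covers fluoro, and none moves a halogen from one position of the phenyl to another, so the steps bear on it only loosely: a halogen swap once cost a large amount and once cost nothing. The range must therefore be wide. A moderate fall is expected, a number 15.7 percentage points lower from compound 3 to compound 4 (beyond the scatter), and compound 4 is estimated at 45%, between 15% and 70%.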

Compound 4, a percentage reported as inhibition, at one concentration (the size of the read-out at that concentration, not a potency): 16.3%
Compound 4: middle estimate off by 28.7 percentage points, on the high side, within the range that was stated.
By their numbers in this assay, from the lowest: compounds 4 and 2 (each within the scatter of the next); then compounds 1 and 3 (each within the scatter of the next).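

Fluoro in place of hydrogen gives a number 43.5 percentage points lower from compound 1 to compound 4 (beyond the scatter) in this assay, and the change from the 4-bromophenyl group gives a number 44.4 percentage points lower from compound 3 to compound 4 (beyond the scatter), so a large fall on this phenyl is not confined to the 4-chlorophenyl group. The 2-fluorophenyl group in place of the 4-chlorophenyl group gives a number 2.2 percentage points lower from compound 2 to compound 4 (within the scatter), so the two halogen compounds cannot be separated, and compound 3 alone among the halogen compounds goes against a fall on halogen substitution. No supporting measurement is available to explain this division of the series into two low and two high compounds.

Still open, as far as these compounds go, is whether the fall in compound 4 follows the fluoro itself or its place on the phenyl, a question that a 4-fluorophenyl or a 2-bromophenyl partner would separate. Also open, from the compounds shown here alone, is how a methoxy, an amine or a carboxylic acid on this phenyl would read in this assay, and whether the split between the chloro and bromo compounds would persist across a full concentration series.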